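The compounds below may be only part of what the source reports. "The series", "measured", "known", "first", "only" and "open" are said of these compounds alone.

- compound 1 `CC(C)(C)CNC(=O)Nc1ccncc1`: 3160 nM
- compound 2 `C[C@@H](/N=C(/S)Nc1ccncc1)C(C)(C)C`: 501 nM

In a functional assay for inhibition, with Rattus norvegicus as the target (a lower number here means a stronger inhibitor, a higher number a weaker inhibitor), compound 2 gives 501 nM, the lower of the two numbers. Compound 1 gives 3160 nM. The gap between these two values lies beyond the scatter. Next in the series is compound 3 `C[C@H](/N=C(/S)Nc1ccncc1)C(C)(C)C`: the two compounds have the same atoms and bonds and differ only in configuration as drawn: 1 of 2 stereo elements differ; a stereocentre at a saturated chain carbon is drawn R in compound 2 and S in compound 3. For the measured compounds named here, no measured pair isolates a change of configuration, so the size of this step is uncertain. A weaker result is expected, with a step beyond the scatter towards a higher number. The expected change is a 4.0-fold higher number from compound 2 to compound 3 (0.60 log units; beyond the scatter). For compound 3 the estimated value is 2000 nM, with an expected range of 600 nM to 8000 nM.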

Compound 3, half-maximal inhibitory concentration: 316 nM
Beside the measured number, compound 3's estimate is 6.3-fold (0.80 log units) above it; measured number outside the range, below it.
By their numbers in this assay, from the lowest: compounds 3 and 2 (each within the scatter of the next); then compound 1.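

The pair isolates a single stereocentre at a saturated chain carbon: the fact that compounds 2 and 3 differ only in the configuration as drawn. In this assay, going from R to S gives a 1.6-fold lower number from compound 2 to compound 3 (0.20 log units; within the scatter), so the drawn configuration at this carbon does not separate the two compounds. Neither configuration can be preferred from these numbers, and a drawn R or S at this position is not a lever on this read-out for this pair. Still open, going by these compounds, is whether the two configurations stay this close when a longer chain or a phenyl group stands on this carbon.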